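This account rests on a few compounds, and the source may have more. Where it says the series, first, only, none or still open, it means among the compounds named here.

In a functional assay on the whole organism for inhibition, with Rattus norvegicus as the target, at a dose of 25 mg/kg (a lower number here means less inhibition, a higher number more inhibition at the dose given (going by the name of the read-out)), compound 1 `COc1cc2[nH]c(=O)c(=O)oc2cc1OC` gives 45%, and compound 2 `COc1ccc2oc(=O)c(=O)[nH]c2c1` gives 21%, the lower of the two numbers. Among the measured compounds shown here, the one measured step, a number 24 percentage points lower from compound 1 to compound 2 (beyond the scatter), turns on the methoxy alone. Compound 3 `CCOC(=O)c1ccc2oc(=O)c(=O)[nH]c2c1` differs from compound 2 by ethoxycarbonyl in place of methoxy on an aromatic carbon. For the measured compounds named here, no measured step swaps one group for another at this carbon, so the step from compound 1 to compound 2 bears only loosely on it, and in this assay a change of modest size, in either direction, is expected: a number 4 percentage points higher from compound 2 to compound 3 (within the scatter). Compound 3 is therefore estimated in this assay at 25%, with a range from 5% to 50%.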

Compound 3, a percentage reported as inhibition, in the whole organism at one dose (the size of the read-out at that dose, not a potency): 0%
For compound 3 the middle estimate is 25 percentage points above the measured one; the whole stated range lies above it.
By their numbers in this assay, from the lowest: compound 3; then compound 2; then compound 1.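

Among the compounds shown here, this is the first exchange of one group for another at this carbon, and in this assay it brings a number 21 percentage points lower from compound 2 to compound 3 (beyond the scatter) rather than a change within the scatter. With compound 3 at 0% no inhibition remains at the dose given, so ethoxycarbonyl does not serve in place of methoxy on this carbon. From the compounds shown here alone, whether an amine, a carboxylic acid or a longer alkoxy chain on this carbon would keep any inhibition stays open. Nothing available here explains the loss.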